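A few compounds are considered here, and "the series" means these few. Any claim that something is new, unique, unknown or untested is made for them only; others in the source may bear on it.

Measured so far:
- compound 1, `CCOc1cc(/C=N/Nc2nc(N)c3ncn([C@@H]4O[C@H](CO)[C@@H](O)[C@H]4O)c3n2)ccc1O`: 6940 nM
- compound 2, `N#Cc1ccccc1/C=N/Nc1nc(N)c2ncn([C@@H]3O[C@H](CO)[C@@H](O)[C@H]3O)c2n1`: 2.9 nM

In an assay on CHO-K1 cells for displacement of a labelled ligand from adenosine receptor A1 (Homo sapiens), read by scintillation counting, with a stated time of 60 min (a lower number here means a stronger inhibitor, a higher number a weaker inhibitor), compound 2 gives 2.9 nM, the lowest of the two numbers; its nearest neighbour is compound 1, and the step from one to the other is a 2400-fold lower number from compound 1 to compound 2 (3.38 log units; beyond the scatter). Compound 3, `Nc1nc(N/N=C/c2ccc(-n3ccnc3)cc2)nc2c1ncn2[C@@H]1O[C@H](CO)[C@@H](O)[C@H]1O`, is not yet measured. The change from compound 2 is 4-(1H-imidazol-1-yl)phenyl in place of 2-cyanophenyl on a carbon with a double bond to nitrogen.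

Among the compounds with values here, only one measured step bears on this change, and it shows that swapping the group on the carbon with a double bond to nitrogen can move the number a great deal: a 2400-fold lower number from compound 1 to compound 2 (3.38 log units; beyond the scatter). The incoming 4-(1H-imidazol-1-yl)phenyl has been seen in neither compound 1 nor compound 2, so the direction is uncertain, but a move away from compound 2 toward higher numbers is expected, of size a 34-fold higher number from compound 2 to compound 3 (1.54 log units; beyond the scatter). Compound 3 is therefore estimated to give 100 nM in this assay, with a likely range from 10 nM to 2000 nM.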

Compound 3, inhibition constant: > 10000 nM
Compound 3: a limit, no number; the forecaster's own chance of this, stated with the estimate: 5%; middle value at least 100-fold (2.00 log units) from the limit.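

For compound 3 the result in this assay is a limit and not a number: the limit of > 10000 nM in this assay, at which 1 of the 3 values shown sits. Even so, the step is readable as an at least 3400-fold higher number from compound 2 to compound 3 (3.53 log units; beyond the scatter), so 4-(1H-imidazol-1-yl)phenyl joins 3-ethoxy-4-hydroxyphenyl as a second group on this carbon with a double bond to nitrogen that stands far from 2-cyanophenyl. The other comparison is an at least 1.4-fold higher number from compound 1 to compound 3 (0.15 log units; that floor lies within the scatter), and with that floor no order can be claimed between these two compounds.

Of the three groups shown, only 2-cyanophenyl gives a low number, so a single compound carries that result, and it remains unknown whether the nitrile is needed or the carbon-only aromatic ring would serve alone. A plain phenyl or a chlorophenyl on this carbon would help to separate those two readings.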